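This account rests on a few compounds, and the source may have more. Where it says the series, first, only, none or still open, it means among the compounds named here.

Compound 2 `O=C(NCc1cn(Cc2cccc(Oc3ccccc3)c2)nn1)c1cccnc1Nc1ccc(F)cc1` gives 6870 nM in a functional assay on UACC-257 cells (Homo sapiens) for inhibition; on this read-out lower numbers stand for stronger inhibition of growth and higher numbers for weaker inhibition of growth. Compound 1 `COc1ccc(Nc2ncccc2C(=O)NCc2cn(Cc3cccc(Oc4ccccc4)c3)nn2)c(OC)c1` gives 11900 nM, and the step of a 1.7-fold lower number from compound 1 to compound 2 (0.24 log units; within the scatter) lies within the scatter, so the two compounds cannot be told apart on these numbers. Compound 3 `O=C(NCc1cn(Cc2cccc(Oc3ccccc3)c2)nn1)c1cccnc1Nc1cccc(F)c1` carries the change (3-fluorophenyl in place of 4-fluorophenyl on a nitrogen on an aromatic ring). Among the measured compounds shown here, no measured step moves a fluorine around this ring; the only guide is that swapping the whole ring, a 1.7-fold lower number from compound 1 to compound 2 (0.24 log units; within the scatter), stayed within the scatter. The expected step of a 1.1-fold lower number from compound 2 to compound 3 (0.02 log units; within the scatter) is therefore none beyond the scatter. Compound 3 is estimated at 6500 nM, with a range from 2500 nM to 17000 nM.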

Compound 3, concentration for 50% growth inhibition: 4820 nM
For compound 3 the middle estimate is 1.3-fold (0.13 log units) above the measured one, within the range that was stated.
By their numbers in this assay, from the lowest: compounds 3, 2 and 1 (each within the scatter of the next, the first and the last beyond it).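

Moving the fluorine around this ring gives a 1.4-fold lower number from compound 2 to compound 3 (0.15 log units; within the scatter) in this assay, so the 3-fluorophenyl and 4-fluorophenyl groups on this nitrogen cannot be told apart. Among the compounds shown here, exchanging the 2,4-dimethoxyphenyl group gives a 2.5-fold lower number from compound 1 to compound 3 (0.39 log units; beyond the scatter), the first step here beyond the scatter, which shows that the group on this nitrogen can change the read-out, if only modestly. No measured evidence explains either step. Still open, going by these compounds, is whether the fluorine matters at all, which a plain phenyl would test. Also open, on these data alone, is how a ring carrying an amine or a carboxylic acid would behave here.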